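The source may report more compounds than this note shows. Statements on the series, on what has been measured and on what is new or still open speak of the compounds shown alone.

Working notes on the series. All three measured compounds share one core and differ only in the group on one aromatic carbon. In a functional assay on CHO cells for agonist activity at metabotropic glutamate receptor 5 (Homo sapiens), read by inositol phosphate accumulation (on this read-out higher numbers stand for weaker inhibition and lower numbers for stronger inhibition), compound 1 `Cc1nc(C#Cc2cncc(Br)c2)cs1` gives 60 nM, compound 2 `COc1ccc(-c2cncc(C#Cc3csc(C)n3)c2)cc1` gives 225 nM, and compound 3 `Cc1nc(C#Cc2cncc(C#CCO)c2)cs1` gives 68.6 nM. Compound 3 thus holds the second highest of the three numbers: its nearest neighbour is compound 1, which sits within the scatter, and its furthest is compound 2, whose higher number lies beyond the scatter. Among the compounds with values here, the only single-point step measured so far is a 1.1-fold higher number from compound 1 to compound 3 (0.06 log units; within the scatter), where 3-hydroxyprop-1-yn-1-yl replaced bromo on that aromatic carbon without moving the number beyond the scatter.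

Compound 4 `C=Cc1cncc(C#Cc2csc(C)n2)c1` is not yet measured. It differs from compound 3 by vinyl in place of 3-hydroxyprop-1-yn-1-yl on an aromatic carbon. Within the data shown here, the one step that bears on this position, the exchange of bromo for 3-hydroxyprop-1-yn-1-yl, was within the scatter, so two quite different small groups there gave nearly the same result; compound 2, with its larger group at the same place, is the only one to give a clearly higher number. Vinyl is another small substituent, so for this assay the step from compound 3 to compound 4 is expected to stay within the scatter, at about a 1.1-fold higher number from compound 3 to compound 4 (0.04 log units; within the scatter). Compound 4 is therefore expected to give 75 nM, with a range from 30 nM to 190 nM.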

Compound 4, half-maximal inhibitory concentration: 2.01 nM
Estimate against measurement, compound 4: 37-fold (1.57 log units) above, outside the stated range (below it).
By their numbers in this assay, from the lowest: compound 4; then compounds 1 and 3 (each within the scatter of the next); then compound 2.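

In this assay this aromatic carbon turns out to be far from indifferent: vinyl in place of 3-hydroxyprop-1-yn-1-yl gives a 34-fold lower number from compound 3 to compound 4 (1.53 log units; beyond the scatter), and vinyl in place of bromo gives a 30-fold lower number from compound 1 to compound 4 (1.47 log units; beyond the scatter), while the exchange of bromo for 3-hydroxyprop-1-yn-1-yl gave only a 1.1-fold higher number from compound 1 to compound 3 (0.06 log units; within the scatter). The near-identical numbers of compound 1 and compound 3 therefore do not describe the position as a whole, since a change at the same place can also move the number far down, and the smallest number of the series now belongs to vinyl. No measurement at hand accounts for this large step.

The compounds shown leave open whether the low number depends on the double bond of vinyl, which an ethyl group on the same aromatic carbon would test, or whether an ethynyl or a propenyl group would serve as well. They also leave open how the number responds when a longer chain or an amine is attached to the vinyl group.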